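Trading diethylamino for (tert-butyl)amino on compound 2

A few compounds are considered here, and "the series" means these few. Any claim that something is new, unique, unknown or untested is made for them only; others in the source may bear on it.

In an ADME assay on CHO cells (Cricetulus griseus) for inhibition, read by MTT assay (on this read-out lower numbers stand for stronger inhibition and higher numbers for weaker inhibition), compound 1 (`CC(C)(C)NCc1cc(Cl)cc(Nc2nc3ccccc3n2Cc2ccc(C(F)(F)F)cc2)c1O`) gives 36300 nM and compound 2 (`CCN(CC)Cc1cc(C)cc(Nc2nc3ccccc3n2Cc2ccc(C(F)(F)F)cc2)c1O`) gives 29300 nM with the two values within the scatter of each other. Compound 3 (`Cc1cc(CNC(C)(C)C)c(O)c(Nc2nc3ccccc3n2Cc2ccc(C(F)(F)F)cc2)c1`) has the same atoms as compound 2 joined differently ((tert-butyl)amino in place of diethylamino on a saturated chain carbon bound to an aromatic carbon) with (tert-butyl)amino in place of diethylamino on a saturated chain carbon bound to an aromatic carbon. Going by the values given here, no measured step isolates this change. Compound 1 also carries (tert-butyl)amino and reads 36300 nM in this assay so no shift beyond the scatter is expected. The expected size of a 1.1-fold higher number from compound 2 to compound 3 (0.04 log units; within the scatter) stays within the scatter. For compound 3 the estimated value is 32000 nM with an expected range from 16000 nM to 64000 nM in this series.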

Compound 3, half-maximal inhibitory concentration in the CHO assay: 30000 nM
Compound 3: middle estimate off by 1.1-fold (0.03 log units), on the high side; measured number inside the range.
By their numbers in the CHO assay, from the lowest: compounds 2, 3 and 1 (each within the scatter of the next).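

In the CHO assay, neither change at its position separates the compounds: (tert-butyl)amino in place of diethylamino gives a 1.0-fold higher number from compound 2 to compound 3 (0.01 log units; within the scatter), and methyl in place of chloro gives a 1.2-fold lower number from compound 1 to compound 3 (0.08 log units; within the scatter). In a physicochemical assay for solubility, read by HPLC, measured as kinetic solubility, with a stated time of 24 h, at pH 6.5 (a higher number here means a more soluble compound, a lower number a less soluble compound), the same amine change gives an at least 10-fold higher number from compound 2 to compound 3 (1.00 log units; beyond the scatter), so the two read-outs part at this saturated chain carbon bound to an aromatic carbon. In the physicochemical assay compound 3 gives 50000 nM as a measured number. In the physicochemical assay compound 2 gives < 5000 nM as a limit of the assay and not a number: the limit of < 5000 nM in the physicochemical assay, at which 1 of the 2 values shown sits.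

As far as these compounds go, the exact size of that step stays open. So does whether isopropylamino or morpholine on this carbon would give the same pair of readings.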